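This account rests on a few compounds, and the source may have more. Where it says the series, first, only, none or still open, it means among the compounds named here.

Within the data shown here, compound 1 `C1CCC(c2nnc3nnc(N4CCCC4)nn23)CC1` carries a cyclohexyl on the shared core and is the only compound here with a full number: in a functional assay on BeWo cells (Homo sapiens) for cytotoxicity, read by MTT assay, with a stated time of 72 h (a higher number here means a weaker inhibitor, a lower number a stronger inhibitor), compound 1 gives 22000 nM. Compound 2 `c1ccc(-c2nnc3nnc(N4CCCC4)n3n2)cc1`, with a phenyl in the same place, reaches in this assay only > 100000 nM, which is a limit and not a number. So compound 1 stands as the sole measured point, and the limit of > 100000 nM in this assay, at which 1 of the 2 values shown sits, marks where the other value sits.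

Compound 3 `Clc1ccccc1-c1nnc2nnc(N3CCCC3)nn12` is not yet measured. It differs from compound 1 by 2-chlorophenyl in place of cyclohexyl on an aromatic carbon; in words, 2-chlorophenyl in place of cyclohexyl on an aromatic carbon. Among the measured compounds shown here, no step between measured compounds is known. Compound 2 shows what a phenyl at that carbon does in this assay, with a value that is only a limit. Against that backdrop a weakening beyond the scatter is expected, a 3.2-fold higher number from compound 1 to compound 3 (0.50 log units; beyond the scatter). Compound 3 is then estimated at 70000 nM in this assay, within a range of 25000 nM to 200000 nM, with a fair chance that only a limit is reported.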

Compound 3, half-maximal inhibitory concentration: 2990 nM
Beside the measured number, compound 3's estimate is 23-fold (1.37 log units) above it; measured number outside the range, below it.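

In this assay, 2-chlorophenyl in place of cyclohexyl on an aromatic carbon gives a 7.4-fold lower number from compound 1 to compound 3 (0.87 log units; beyond the scatter), so this carbon can carry a six-membered aromatic ring and still give a lower number than cyclohexyl does. Among these compounds, this is the first step at this position that can be read as a number, and it points toward a stronger inhibitor: modest in size, yet beyond the usual scatter. Compound 2, with a phenyl on its core, gives only a limit and not a number, so the compounds shown do not tie the lower number to every aromatic ring at this place: the limit of > 100000 nM in this assay, at which 1 of the 3 values shown sits.

As far as these compounds go, what remains open is how much of the step belongs to the chlorine and how much to the aromatic ring, since no measured number is available for a plain phenyl on the core of compound 1. The compounds shown also leave open how this carbon would respond to a 4-methoxyphenyl, a pyridyl ring, a carboxylic acid or a longer chain such as n-butyl.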